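A few compounds are considered here, and "the series" means these few. Any claim that something is new, unique, unknown or untested is made for them only; others in the source may bear on it.

In a physicochemical assay for solubility, measured as thermodynamic solubility, at pH 6.8 (on this read-out higher numbers stand for higher solubility and lower numbers for lower solubility), compound 1 (`C[C@H](NC(=O)COc1cc(C(F)(F)F)c2c(-c3ccccn3)nn(C)c2n1)c1ccccc1`) gives 40000 nM and compound 2 (`Cc1ccc([C@H](C)NC(=O)COc2cc(C)c3c(-c4ncccn4)nn(C)c3n2)cc1`) gives 43000 nM, two values that lie within the scatter of each other. Going by the values given here, compound 2 thus stands level with the only other measured compound. Compound 3 (`Cc1ccc([C@H](C)NC(=O)COc2cc(C)c3c(-c4cnccn4)nn(C)c3n2)cc1`) comes from compound 2 by a single change, pyrazin-2-yl in place of pyrimidin-2-yl on an aromatic carbon, with the same atoms joined differently. Among the compounds with values here, no measured pair of compounds isolates this change, so this assay offers no direct precedent for it. The expectation rests on compound 2 at 43000 nM and on the matching counts of the two groups. The estimated move, a 1.2-fold lower number from compound 2 to compound 3 (0.09 log units; within the scatter), is not expected to go beyond the scatter. For compound 3 the expected value is 35000 nM, with an estimated range from 12000 nM to 90000 nM.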

Compound 3, solubility: 115000 nM
Compound 3: middle estimate off by 3.3-fold (0.52 log units), on the low side, outside the stated range (above it).
By their numbers in this assay, from the lowest: compounds 1 and 2 (each within the scatter of the next); then compound 3.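

In this assay this position proves responsive to a change that leaves every counted feature the same: pyrazin-2-yl in place of pyrimidin-2-yl gives a 2.7-fold higher number from compound 2 to compound 3 (0.43 log units; beyond the scatter) even though the two groups match in heavy atoms, hetero atoms, hydrogen-bond donors and acceptors. The two compounds have the same atoms joined differently, and this one ring on the aromatic carbon is the only place where they differ. Nothing at hand accounts for the step, so the data record its size and direction but offer no explanation for it.

As far as these compounds go, what a phenyl ring or a pyridazin-3-yl group would give at this position remains open. So does whether the same step would appear with a trifluoromethyl group in place of the methyl group on the shared core.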